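From chloro to iodo: an estimate for compound 4

The source may hold more compounds than are shown below. What is called first, only, known or untested is meant among the compounds shown, and "the series" means these compounds.

Compound 1 `C=C(Br)C(=O)Nc1ccc(/C=C/C(=O)c2ccc(I)cc2)cc1` gives 8300 nM
Compound 2 `Nc1ccc(/C=C/C(=O)c2ccc(Cl)cc2)cc1` gives 178000 nM
Compound 3 `Nc1ccc(/C=C/C(=O)c2ccc(Cl)c(Cl)c2)cc1` gives 33000 nM

In a functional assay on FM3A cells (Mus musculus) for antiproliferative activity, with a stated time of 48 h (on this read-out higher numbers stand for weaker inhibition and lower numbers for stronger inhibition), compound 2 stands highest of the three, at 178000 nM. Compound 4 `Nc1ccc(/C=C/C(=O)c2ccc(I)cc2)cc1` differs from it by one change: iodo in place of chloro on an aromatic carbon. Going by the values given here, no measured step makes this exact exchange. The closest evidence is a 5.4-fold lower number from compound 2 to compound 3 (0.73 log units; beyond the scatter), a different change, chloro in place of hydrogen on an aromatic carbon. Compound 1 also carries iodo and gives 8300 nM, but it differs elsewhere too. A modest step to a lower number in this assay is therefore expected, though one within the scatter remains possible. The estimated step is a 3.0-fold lower number from compound 2 to compound 4 (0.47 log units; beyond the scatter). For compound 4 the expected value is 60000 nM, with an estimated range of 18000 nM to 180000 nM.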

Compound 4, half-maximal inhibitory concentration: 110000 nM
Beside the measured number, compound 4's estimate is 1.8-fold (0.26 log units) below it; measured number inside the range.
By their numbers in this assay, from the lowest: compound 1; then compound 3; then compounds 4 and 2 (each within the scatter of the next).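

In this assay, iodo in place of chloro at this position, on an aromatic carbon para to a large group, gives a 1.6-fold lower number from compound 2 to compound 4 (0.21 log units; within the scatter) and so does not separate the two compounds. With iodo held fixed, hydrogen in place of (1-bromoethenyl)carbonyl on the nitrogen gives a 13-fold higher number from compound 1 to compound 4 (1.12 log units; beyond the scatter) as a large step. Nothing available explains either result. Still open, on these data alone, is how a methoxy group or a fluoro group would read at this position, and whether the (1-bromoethenyl)carbonyl group gives a step of similar size when chloro replaces iodo.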